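Compound 4: a Free Hydroxyl Enters, Measured Against a Limit

The compounds below may be only part of what the source reports. "The series", "measured", "known", "first", "only" and "open" are said of these compounds alone.

Compound 1, `COc1ccc(/C=C2\CCC/C(=C\c3cccc(Cl)c3)C2=O)cc1OC`, in a functional assay on A549 cells (Homo sapiens) for cytotoxicity, read by MTT assay, with a stated time of 72 h (a lower number here means a stronger inhibitor, a higher number a weaker inhibitor), gives 11000 nM.
Compound 2, `COc1ccc(/C=C2\CCC/C(=C\c3ccccc3Br)C2=O)cc1OC`, gives in this assay only a limit of the assay, > 20000 nM.
Compound 3, `COc1ccc(/C=C2\CCC/C(=C\c3ccc(OC)c(OC)c3)C2=O)cc1`, gives in this assay only a limit of the assay, > 20000 nM.

Compound 3 therefore stands at the edge of what this assay reports, not at a number, and it shares that place with one other compound (the limit of > 20000 nM in this assay, at which 2 of the 3 values shown sit). The steps into compound 3 are known only as floors: an at least 1.8-fold higher number from compound 1 to compound 3 (0.25 log units; that floor lies within the scatter), while a step that the two limits leave unreadable from compound 2 to compound 3. Compound 4, `COc1cc(/C=C2\CCC/C(=C\c3ccc(OC)c(OC)c3)C2=O)ccc1O`, differs from compound 3 in one place: 4-hydroxy-3-methoxyphenyl in place of 4-methoxyphenyl on a double-bonded chain carbon bound to a double-bonded ring carbon. Going by the values given here, none of the measured steps changes the 4-methoxyphenyl for a group with a hydroxyl, so no measured step gives the size of this change. The step from compound 3 into compound 4 is expected to be a number no higher from compound 3 to compound 4 (the limit leaves the size open), none beyond the scatter, since compound 3 itself shows only a limit > 20000 nM. Compound 4 is accordingly expected to give about 20000 nM in this assay, between 8000 nM and 50000 nM, most likely again as a limit.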

Compound 4, half-maximal inhibitory concentration: 10300 nM
The estimate for compound 4 lay 1.9-fold (0.29 log units) above the measured number; low and high end bracket the measured number.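

In this assay, compound 2 and compound 3 are held at a single limit of the assay: the limit of > 20000 nM in this assay, at which 2 of the 4 values shown sit. With 4-hydroxy-3-methoxyphenyl in place of 4-methoxyphenyl on a double-bonded chain carbon bound to a double-bonded ring carbon, the series gains a second measured number, yet this change can be stated only as an at least 1.9-fold lower number from compound 3 to compound 4 (0.28 log units; that floor lies within the scatter), and the same holds for an at least 1.9-fold lower number from compound 2 to compound 4 (0.28 log units; that floor lies within the scatter). The 4-hydroxy-3-methoxyphenyl and 3-chlorophenyl groups cannot be told apart here, with a 1.1-fold lower number from compound 1 to compound 4 (0.03 log units; within the scatter).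

The compounds shown leave open how much of the change belongs to the hydroxyl and how much to the methoxy group that enters with it. They also leave open what an amine or a carboxylic acid would give at this position.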